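Chloro in place of hydroxy: compound 2 to compound 3

A few compounds are considered here, and "the series" means these few. Any claim that something is new, unique, unknown or untested is made for them only; others in the source may bear on it.

Compound 1 `COc1ccc(-c2nc3ccccn3c2NC2CCCCC2)cc1` gives 7610 nM in an assay on membranes from brain for displacement of a labelled ligand from adenosine receptor A1 (Rattus norvegicus); on this read-out higher numbers stand for weaker inhibition and lower numbers for stronger inhibition; compound 2 `Oc1ccc(-c2nc3ccccn3c2NC2CCCCC2)cc1` gives 5530 nM. Within the data shown here, the single measured step, a 1.4-fold lower number from compound 1 to compound 2 (0.14 log units; within the scatter), lies within the scatter, so compound 2 carries the smaller of the two numbers without standing apart from compound 1. Compound 3 `Clc1ccc(-c2nc3ccccn3c2NC2CCCCC2)cc1` differs from compound 2 by chloro in place of hydroxy on an aromatic carbon, read one bond further out as 4-hydroxyphenyl to 4-chlorophenyl. Among the measured compounds shown here, no measured step covers this exchange; the one change made at the same aromatic carbon stayed within the scatter. No shift beyond the scatter is therefore expected, a 1.1-fold lower number from compound 2 to compound 3 (0.04 log units; within the scatter). Compound 3 is estimated at 5000 nM, with a range of 1500 nM to 16000 nM.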

Compound 3, inhibition constant: > 100000 nM
Compound 3 gave a limit, no number; the forecaster's own chance of this, stated with the estimate: 5%; at least 20-fold (1.30 log units) between middle value and limit.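

Compound 3 stands at a limit of the assay, not a number, in this assay: the limit of > 100000 nM in this assay, at which 1 of the 3 values shown sits.

Chloro in place of hydroxy gives an at least 18-fold higher number from compound 2 to compound 3 (1.25 log units; beyond the scatter), and chloro in place of methoxy gives an at least 13-fold higher number from compound 1 to compound 3 (1.11 log units; beyond the scatter). This aromatic carbon, para to a large group, therefore does respond to the group it carries, which the step within the scatter between hydroxy and methoxy did not show.

On these data alone, the true size of both steps stays open, as does whether an amine, a carboxylic acid or a bare hydrogen here would stand with hydroxy and methoxy or with chloro.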